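Fluoro for hydrogen on a nitrofuran amide: stability outlook

The source may hold more compounds than are shown below. What is called first, only, known or untested is meant among the compounds shown, and "the series" means these compounds.

Compound 2 `COc1ccn2c(-c3ccc(NC(=O)c4ccc([N+](=O)[O-])o4)cc3)cnc2c1` is the longer-lived of the two measured compounds: in an ADME assay on microsomes from liver (Homo sapiens) for metabolic stability (on this read-out lower numbers stand for a shorter-lived compound and higher numbers for a longer-lived compound), compound 2 gives 0.472 h. Going by the values given here, its only neighbour, compound 1 `CC(=O)N1CC=C(c2ccn3c(-c4ccc(NC(=O)c5ccc([N+](=O)[O-])o5)cc4)cnc3c2)CC1`, gives 0.225 h in this assay, and the single measured step, a 2.1-fold higher number from compound 1 to compound 2 (0.32 log units; beyond the scatter), came with a two-heavy-atom group replacing a nine-heavy-atom ring group on the shared core. Compound 3 `COc1ccn2c(-c3ccc(NC(=O)c4ccc([N+](=O)[O-])o4)cc3F)cnc2c1` differs from compound 2 by fluoro in place of hydrogen on an aromatic carbon. Among the compounds with values here, no measured step concerns a fluoro for a hydrogen, and the one step that exists involves a different part of the molecule, so it offers no guide in direction. With nothing in the data pointing either way, compound 3 is expected to give a half-life in this assay close to that of compound 2, a step of a 1.1-fold higher number from compound 2 to compound 3 (0.03 log units; within the scatter). The estimate for compound 3 is 0.5 h, with a range from 0.25 h to 1 h.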

Compound 3, half-life: 0.428 h
Beside the measured number, compound 3's estimate is 1.2-fold (0.07 log units) above it; the measured number falls inside the stated range.
By their numbers in this assay, from the lowest: compounds 1, 3 and 2 (each within the scatter of the next, the first and the last beyond it).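

Fluoro in place of hydrogen on this aromatic carbon, ortho to a large group and meta to a large group, is the first change at this place, and in this assay it gives a 1.1-fold lower number from compound 2 to compound 3 (0.04 log units; within the scatter) and so no shift that stands clear of the scatter. On this single step, the position accepts a fluoro with the half-life holding, which the earlier step, made in a different part of the molecule, could not show. Nothing available here accounts for this outcome.

Going by these compounds, whether another group at this place, such as chloro, methoxy or trifluoromethyl, would hold the half-life in the same way stays open. So does whether an amine in place of the nitro group would move the number at all.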